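The source may report more compounds than this note shows. Statements on the series, on what has been measured and on what is new or still open speak of the compounds shown alone.

Three compounds have been measured in a functional assay on MCF7 cells (Homo sapiens) for antiproliferative activity, read by MTT assay, with a stated time of 24 h; on this read-out lower numbers stand for stronger inhibition and higher numbers for weaker inhibition:
compound 1, `CCCCc1oc2ccccc2c1C(=O)c1ccc(OCCCC(=O)N2CCCC2)cc1`, gives 23500 nM;
compound 2, `CCCCc1oc2ccccc2c1C(=O)c1ccc(OCCCC(=O)N2CCCCC2)cc1`, gives 33000 nM;
compound 3, `CCCCc1oc2ccccc2c1C(=O)c1ccc(OCCCC(=O)NCc2ccccc2)cc1`, gives 49700 nM.

Compound 3 gives the highest of the three numbers: its step from compound 2 is a 1.5-fold higher number from compound 2 to compound 3 (0.18 log units; within the scatter), and from compound 1 it is a 2.1-fold higher number from compound 1 to compound 3 (0.33 log units; beyond the scatter). Compound 4, `CCCCc1oc2ccccc2c1C(=O)c1ccc(OCCCC(=O)N[C@@H](C)c2ccccc2)cc1`, differs from compound 3 by methyl in place of hydrogen on a saturated chain carbon bound to an amide-type nitrogen and an aromatic carbon. Within the data shown here, none of the measured steps touches this saturated chain carbon; all three exchange the whole group on the carbonyl carbon, and even those exchanges stay small, the largest being a 2.1-fold higher number from compound 1 to compound 3 (0.33 log units; beyond the scatter). A single methyl added here is therefore expected to move this assay little, with no step beyond the scatter in either direction. The estimated step is a 1.0-fold higher number from compound 3 to compound 4 (0.00 log units; within the scatter). Compound 4 is thus estimated at 50000 nM, with a range from 25000 nM to 100000 nM.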

Compound 4, half-maximal inhibitory concentration: > 50000 nM
Compound 4 was reported as a limit (the forecaster's own chance of this, stated with the estimate: 10%); the middle value sits exactly at the limit.
By their numbers in this assay, from the lowest: compounds 1, 2 and 3 (each within the scatter of the next, the first and the last beyond it). At a limit, above all of these: compound 4.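

The methyl on this saturated chain carbon is the first change to touch that carbon, and compound 4 is reported only as a limit in this assay: the limit of > 50000 nM in this assay, at which 1 of the 4 values shown sits.

Among these compounds, the step for the methyl itself is a number no lower from compound 3 to compound 4 (the limit leaves the size open); it cannot be read for size and shows only that the number did not fall. Exchanging the whole group on the carbonyl carbon gives an at least 1.5-fold higher number from compound 2 to compound 4 (0.18 log units; that floor lies within the scatter) and an at least 2.1-fold higher number from compound 1 to compound 4 (0.32 log units; beyond the scatter).

The compounds shown leave open whether ethyl or hydroxymethyl on this carbon would lower the number. Also open, going by these compounds, is whether the mirror-image form of the (1-phenylethyl)amino group would read differently.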